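Trifluoromethoxy for trifluoromethyl on two cores

This account rests on a few compounds, and the source may have more. Where it says the series, first, only, none or still open, it means among the compounds named here.

Measured compounds:
compound 1, `CC(O)(CSc1cccc(C(F)(F)F)c1)C(=O)Nc1ccc(S(F)(F)(F)(F)F)cc1`, 26200 nM
compound 2, `CC(O)(CSc1cccc(OC(F)(F)F)c1)C(=O)Nc1ccc(S(F)(F)(F)(F)F)cc1`, 23800 nM
compound 3, `CC(O)(COc1ccc(C(F)(F)F)cc1)C(=O)Nc1cccc(S(F)(F)(F)(F)F)c1`, 13600 nM

All three were run in a functional assay on DU-145 cells (Homo sapiens) for antiproliferative activity, read by propidium iodide staining, with a stated time of 96 h; on this read-out higher numbers stand for weaker inhibition and lower numbers for stronger inhibition. Compound 1 gives 26200 nM and compound 2 gives 23800 nM; compound 3, on a different core, gives 13600 nM. The three values sit close together, and none of the gaps between them is larger than the usual scatter of this assay.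

Compound 1 and compound 2 differ in one place, (trifluoromethoxy in place of trifluoromethyl on an aromatic carbon). The step is a 1.1-fold lower number from compound 1 to compound 2 (0.04 log units; within the scatter).

Compound 3 and compound 1 differ in more than one place; the difference between the two cores is not broken down here.

Compound 4, `CC(O)(COc1ccc(OC(F)(F)F)cc1)C(=O)Nc1cccc(S(F)(F)(F)(F)F)c1`, is not yet measured. It stands to compound 3 as compound 2 stands to compound 1: trifluoromethoxy in place of trifluoromethyl on an aromatic carbon. The place is not identical in its surroundings: on the core of compound 1 the group is meta to a large group, on the core of compound 3 it is para to a large group, so this is the same kind of change rather than the same change.

For the measured compounds named here, the only measured case of this change, the step from compound 1 to compound 2, stays within the scatter, and nothing among the measured compounds points to a different size on the core of compound 3. The step from compound 3 to compound 4 in this assay is therefore expected to be about a 1.1-fold lower number from compound 3 to compound 4 (0.04 log units; within the scatter), resting on a 1.1-fold lower number from compound 1 to compound 2 (0.04 log units; within the scatter). Compound 4 is estimated at 12500 nM in this assay, with a range from 6000 nM to 26000 nM.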

Compound 4, half-maximal inhibitory concentration: 19100 nM
Compound 4: middle estimate off by 1.5-fold (0.18 log units), on the low side; measured number inside the range.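

In this assay, trifluoromethoxy in place of trifluoromethyl on the core of compound 3 gives a 1.4-fold higher number from compound 3 to compound 4 (0.15 log units; within the scatter), so on this core, as on the core of compound 1, the step stays inside the scatter. Set side by side, the two steps cannot be told apart, and on these two cores the change reads as a step too small to resolve, whether the group sits on one core or the other: the same change on two cores in this assay, a 1.1-fold lower number (0.04 log units; within the scatter) from compound 1 to compound 2 and a 1.4-fold higher number (0.15 log units; within the scatter) from compound 3 to compound 4, 1.5-fold (0.19 log units) apart, within the scatter of two such steps. For the compounds shown here, this does not show that the step has one fixed size across the series or that it has a direction, and it rests on only two pairs, whose surroundings at the place of change are not the same.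

Still open, going by these compounds, is how other groups would behave at the same place on an aromatic carbon, for instance a nitrile, a chlorine or a methyl in place of trifluoromethyl, and whether any of them would move the read-out beyond the scatter. Also open is what separates the two cores, as no pair among the compounds shown isolates the sulfur linker from the oxygen linker or any other single difference between them.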